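Swapping the 4-bromophenyl of compound 1

The source may report more compounds than this note shows. Statements on the series, on what has been measured and on what is new or still open speak of the compounds shown alone.

Going by the values given here, in a functional assay on Caco-2 cells (Homo sapiens) for inhibition, read by MTT assay, with a stated time of 48 h (on this read-out higher numbers stand for weaker inhibition and lower numbers for stronger inhibition), compound 1 `COc1cc(/C=N/Nc2nc(-c3ccc(Br)cc3)cs2)cc(Br)c1OC` gives 36200 nM, the only actual number available so far. Compound 2 `COc1cc(/C=N/Nc2nc(-c3cc(C(F)(F)F)cc(C(F)(F)F)c3)cs2)cc(Br)c1OC` reads > 100000 nM, which is a limit of the assay and not a number. Compound 1 therefore has no measured number to be set against.

Compound 3 `COc1ccccc1-c1csc(N/N=C/c2cc(Br)c(OC)c(OC)c2)n1` keeps the core of compound 1 but carries 2-methoxyphenyl in place of 4-bromophenyl on an aromatic carbon, next to the ring nitrogen (2-methoxyphenyl in place of 4-bromophenyl on an aromatic carbon). Among the compounds with values here, no measured pair of compounds differing in one place exists to size such a change, so the expectation stays cautious. The estimated step of a 1.0-fold lower number from compound 1 to compound 3 (0.01 log units; within the scatter) in this assay is expected to lie within the usual scatter, with no clear direction. For compound 3 the expected value is 35000 nM, with an estimated range from 11000 nM to 100000 nM.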

Compound 3, half-maximal inhibitory concentration: > 100000 nM
Compound 3 was reported as a limit; the forecaster's own chance of this, stated with the estimate: 15%; middle value at least 2.8-fold (0.45 log units) from the limit.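

The change at this place, on an aromatic carbon next to the ring nitrogen, now has its first size in this assay: 2-methoxyphenyl in place of 4-bromophenyl gives an at least 2.7-fold higher number from compound 1 to compound 3 (0.44 log units; beyond the scatter). The value of compound 3 is a limit of the assay and not a number, so this step marks only the smallest change consistent with it. Compound 1 remains the only one of the three compounds with an actual number, and how far the others lie from it cannot be read: the limit of > 100000 nM in this assay, at which 2 of the 3 values shown sit.

The compounds shown leave open whether the step follows from the loss of the bromine or from the arrival of the methoxy group. They also leave open whether an amine or a carboxylic acid on that phenyl ring would give a measurable number.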